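The source may hold more compounds than are shown below. What is called first, only, known or untested is meant among the compounds shown, and "the series" means these compounds.

Among the compounds with values here, compound 3, with the structure `COc1cccc(OC)c1OCCNCCOc1ccccc1OCc1ccc([N+](=O)[O-])cc1`, gives 8.58 in a functional assay on Vas deferens for antagonist activity at Alpha-1A adrenergic receptor (Rattus norvegicus) (a higher number here means a more potent compound, by a factor of ten per unit of this negative logarithm, a lower number a less potent compound), the highest of the three numbers measured so far. Its nearest neighbour is compound 2, `COc1cccc(OC)c1OCCNCCOc1ccccc1OCc1ccccc1[N+](=O)[O-]`, which gives 8.2; the step of a number 0.38 log units higher from compound 2 to compound 3 (beyond the scatter) lies beyond the scatter. Furthest away is compound 1, `COc1cccc(OC)c1OCCNCCOc1ccccc1OCc1ccccc1C`, which gives 7.81; the step of a number 0.77 log units higher from compound 1 to compound 3 (beyond the scatter) is also beyond the scatter, as is a number 0.39 log units higher from compound 1 to compound 2 (beyond the scatter).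

Compound 4, `COc1cccc(COc2ccccc2OCCNCCOc2c(OC)cccc2OC)c1`, has not been measured yet. Compared with compound 3, the change is 3-methoxyphenyl in place of 4-nitrophenyl on a saturated chain carbon bound to an oxygen on an aromatic ring. Within the data shown here, none of the measured steps contains a methoxyphenyl group, so there is no direct guide. The steps that come closest are those in which the 4-nitrophenyl group was replaced: both a number 0.38 log units higher from compound 2 to compound 3 (beyond the scatter) and a number 0.77 log units higher from compound 1 to compound 3 (beyond the scatter) show that compound 3 sits above its relatives, so a return to a different substituent is expected to bring a modest loss in this assay. Compound 4 is therefore expected to give about 8, within a range from 7.5 to 8.5, which would be a step of a number 0.58 log units lower from compound 3 to compound 4 (beyond the scatter).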

Compound 4, negative logarithm of the antagonist equilibrium constant: 8.3
Estimate against measurement, compound 4: 0.30 log units below; low and high end bracket the measured number.
By their numbers in this assay, from the lowest: compound 1; then compounds 2, 4 and 3 (each within the scatter of the next, the first and the last beyond it).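

In this assay, a nitro group is not needed at this position to reach the level of compound 2 and compound 3: 3-methoxyphenyl in place of 4-nitrophenyl gives a number 0.28 log units lower from compound 3 to compound 4 (within the scatter) and 3-methoxyphenyl in place of 2-nitrophenyl gives a number 0.10 log units higher from compound 2 to compound 4 (within the scatter) here. Against the 2-methylphenyl group, the same 3-methoxyphenyl group gives a number 0.49 log units higher from compound 1 to compound 4 (beyond the scatter) and so joins the two nitro compounds, leaving compound 1 as the only one beyond the scatter of all three others. Nothing measured here accounts for these steps.

Within the data shown here, with the methoxy group seen only in 3-methoxyphenyl, it remains open how 2-methoxyphenyl or 4-methoxyphenyl would compare. Also open, going by these compounds, is how a plain phenyl, a pyridine ring or a phenyl bearing a carboxylic acid would fare at this position.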